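A few compounds are considered here, and "the series" means these few. Any claim that something is new, unique, unknown or untested is made for them only; others in the source may bear on it.

In a functional assay on DU-145 cells (Homo sapiens) for inhibition, read by trypan blue exclusion, with a stated time of 96 h (a higher number here means a weaker inhibitor of growth, a lower number a stronger inhibitor of growth), compound 3 `O=C(/C(=C\c1ccc(Br)cc1)Sc1ccc(Br)cc1)c1ccc(Br)cc1` gives 1000 nM, level with compound 1 `COc1cc(/C=C(/Sc2ccc(Br)cc2)C(=O)c2ccc(Br)cc2)ccc1O` at 1000 nM, while compound 2 `COc1ccc(/C=C(/Sc2ccc(Br)cc2)C(=O)c2ccc(Br)cc2)cc1` gives 25000 nM. Compound 4 `O=C(/C(=C\c1ccc(Br)c(O)c1)Sc1ccc(Br)cc1)c1ccc(Br)cc1` is reached from compound 3 by hydroxy in place of hydrogen on an aromatic carbon, ortho to a bromo group. For the measured compounds named here, no measured step isolates this change. The nearest evidence is no change at the digits printed from compound 1 to compound 3 (within the scatter), so a hydroxy-bearing group and a 4-bromophenyl group read alike there. Against this stand a 25-fold higher number from compound 1 to compound 2 (1.40 log units; beyond the scatter) and a 25-fold lower number from compound 2 to compound 3 (1.40 log units; beyond the scatter), which show that changes on this same aromatic ring can be large. No step beyond the scatter is therefore expected, with the direction open. Compound 4 is estimated at 800 nM, with an expected range of 250 nM to 3000 nM. This estimate means an expected 1.3-fold lower number from compound 3 to compound 4 (0.10 log units; within the scatter).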

Compound 4, concentration for 50% growth inhibition: 1000 nM
The estimate for compound 4 lay 1.3-fold (0.10 log units) below the measured number; measured number inside the range.
By their numbers in this assay, from the lowest: compounds 1, 3 and 4 (each within the scatter of the next); then compound 2.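

Hydroxy in place of hydrogen on the 4-bromophenyl group, ortho to the bromo group, gives a flat step in this assay (no change at the digits printed from compound 3 to compound 4 (within the scatter)). The 4-bromo-3-hydroxyphenyl group reads alike with the 4-hydroxy-3-methoxyphenyl group (no change at the digits printed from compound 1 to compound 4 (within the scatter)) and stands well apart from the 4-methoxyphenyl group (a 25-fold lower number from compound 2 to compound 4 (1.40 log units; beyond the scatter)). Nothing on hand accounts for these readings. Going by these compounds, whether an amine or a carboxylic acid at this same place would also read alike stays open. So does whether hydroxy gives the same flat step without the bromo group.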